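A few compounds are considered here, and "the series" means these few. Any claim that something is new, unique, unknown or untested is made for them only; others in the source may bear on it.

Compound 2 `c1ccc(COc2ccc(Cc3ccc(NC4=NCCN4)cc3)cc2)cc1` is the weaker of the two compounds measured in a functional assay on SH-SY5Y cells (Homo sapiens) for antagonist activity, read by cAMP accumulation (on this read-out higher numbers stand for higher potency (the scale is a negative logarithm) and lower numbers for lower potency), giving 7.7. Going by the values given here, compound 1 `CCOc1ccc(Cc2ccc(NC3=NCCN3)cc2)cc1` stands above it in this assay, giving 8.2, and the single step between them, a number 0.50 log units lower from compound 1 to compound 2 (beyond the scatter), is the only measured change at the oxygen on the aromatic ring.

Compound 3 `c1cc(NC2=NCCN2)ccc1Cc1ccc(OC2CCCC2)cc1` is the next compound to be measured. Relative to compound 2 the change is cyclopentyl in place of benzyl on an oxygen on an aromatic ring, so compound 3 carries neither the methyl of compound 1 nor the benzyl of compound 2 on that oxygen.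

Among the compounds with values here, the one step that bears on this position, from compound 1 to compound 2, was modest and went down when benzyl replaced the smaller group. Within the data shown here, compound 3 moves away from benzyl again, and the expectation is that the number moves partly back toward compound 1 rather than farther down, though no measured pair shows a cyclopentyl at this place. Compound 3 is therefore expected to give 8, within 7.5 to 8.5, a step of a number 0.30 log units higher from compound 2 to compound 3 (within the scatter) that is estimated, not measured.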

Compound 3, negative logarithm of the antagonist equilibrium constant: 8.9
The estimate for compound 3 lay 0.90 log units below the measured number; the measured number lies above the stated range.
By their numbers in this assay, from the lowest: compound 2; then compound 1; then compound 3.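

In this assay, replacing benzyl with cyclopentyl on the oxygen gives a number 1.20 log units higher from compound 2 to compound 3 (beyond the scatter), the largest step seen so far at this position, and it more than reverses the earlier fall of a number 0.50 log units lower from compound 1 to compound 2 (beyond the scatter). Replacing ethyl with cyclopentyl gives a number 0.70 log units higher from compound 1 to compound 3 (beyond the scatter), so a ring on this oxygen does not in itself lower the number: the five-membered non-aromatic ring of compound 3 stands above both the ethyl of compound 1 and the benzyl of compound 2, and the earlier pair alone could not have shown that this position can go above compound 1. No measurement at hand explains why cyclopentyl stands so far above benzyl and ethyl here.

With one cyclopentyl compound, the rise cannot yet be tied to the ring itself, to its five-membered form or to the oxygen bearing a ring carbon directly rather than through a chain carbon. As far as these compounds go, it also remains open whether cyclobutyl, cyclohexyl, isopropyl or a longer chain such as pentyl on this oxygen would stand nearer compound 3 or compound 1.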